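Amide side chain: 4-chlorobenzyl to propyl

This account rests on a few compounds, and the source may have more. Where it says the series, first, only, none or still open, it means among the compounds named here.

Compound 1 `C=CC1=C(C(=O)NCc2ccc(Cl)cc2)C(c2ccc(OC)c(OC)c2)OC1`, compound 2 `C=CC1=C(C(=O)NCc2ccc(Cl)cc2)C(c2ccc(OC)cc2)OC1` and compound 3 `C=CC1=C(C(=O)NCc2ccc(OC)c(OC)c2)C(c2ccc(OC)cc2)OC1` share one core and differ only in their methoxy and amide substituents. In a functional assay on A549 cells (Homo sapiens) for cytotoxicity, read by MTT assay, with a stated time of 24 h (on this read-out lower numbers stand for stronger inhibition and higher numbers for weaker inhibition), compound 1 gives only the assay limit > 100000 nM. Compound 2 likewise reaches only the limit > 100000 nM in this assay. Compound 3 also stops at the limit > 100000 nM. The step that the two limits leave unreadable from compound 1 to compound 2 is unreadable, as all three values sit at the limit of > 100000 nM in this assay, at which 3 of the 3 values shown sit. Compound 4 `C=CC1=C(C(=O)NCCC)C(c2ccc(OC)cc2)OC1`, not yet measured, differs from compound 2 by ethyl in place of 4-chlorophenyl on a saturated chain carbon bound to an amide-type nitrogen. Among the measured compounds shown here, no measured step bears on this change; every value shown is a limit, so no step beyond the scatter can be read from them. Compound 4 is expected to remain at the limit, with an estimated 150000 nM (range 50000 nM to 500000 nM). The step that the limit leaves unreadable from compound 2 to compound 4 is expected to be none beyond the scatter.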

Compound 4, half-maximal inhibitory concentration: > 100000 nM
Compound 4 was reported as a limit; the forecaster's own chance of this, stated with the estimate: 85%; the middle value lies beyond the limit too.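

Compound 4 also gives the limit > 100000 nM in this assay and so no step from compound 2 to compound 4 can be read: the limit of > 100000 nM in this assay, at which 4 of the 4 values shown sit.

As far as these compounds go, whether any substituent on the shared core gives a value inside the range of this assay remains open.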